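Working notes: from compound 2 to compound 4

The compounds below may be only part of what the source reports. "The series", "measured", "known", "first", "only" and "open" are said of these compounds alone.

- compound 1 `C=C1CCC[C@]2(C)CCC(c3cn(-c4ccc(C(C)=O)cc4)nn3)=CC[C@@]12C`: 15100 nM
- compound 2 `C=C1CCC[C@]2(C)CCC(c3cn(-c4ccccc4C(C)=O)nn3)=CC[C@@]12C`: 55700 nM
- compound 3 `C=C1CCC[C@]2(C)CCC(c3cn(CC(=O)Nc4ccc(C)cc4)nn3)=CC[C@@]12C`: 131000 nM

In a functional assay on HeLa cells (Homo sapiens) for cytotoxicity, read by MTT assay, with a stated time of 48 h (on this read-out higher numbers stand for weaker inhibition and lower numbers for stronger inhibition), compound 2, at 55700 nM, stands second highest of the three, under compound 3 and over compound 1. Next is compound 4 `C=C1CCC[C@]2(C)CCC(c3cn(-c4ccc(C)cc4)nn3)=CC[C@@]12C`, with 4-methylphenyl in place of 2-acetylphenyl on an aromatic nitrogen. For the measured compounds named here, one measured step bears on this: a 3.7-fold higher number from compound 1 to compound 2 (0.57 log units; beyond the scatter), modest and beyond the scatter. Going by the values given here, compound 1 carries 4-acetylphenyl and compound 4 carries 4-methylphenyl, but no measured step compares these two groups. A step of similar or smaller size towards a lower number is therefore expected, and the expected step is a 2.2-fold lower number from compound 2 to compound 4 (0.35 log units; beyond the scatter). For compound 4 the estimate is 25000 nM, with an expected range of 9000 nM to 70000 nM.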

Compound 4, half-maximal inhibitory concentration: 69100 nM
For compound 4 the middle estimate is 2.8-fold (0.44 log units) below the measured one, within the range that was stated.
By their numbers in this assay, from the lowest: compound 1; then compounds 2, 4 and 3 (each within the scatter of the next, the first and the last beyond it).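

In this assay there is a 1.2-fold higher number from compound 2 to compound 4 (0.09 log units; within the scatter), so on this aromatic nitrogen 4-methylphenyl and 2-acetylphenyl cannot be told apart. Methyl in place of acetyl on the aromatic carbon does register, with a 4.6-fold higher number from compound 1 to compound 4 (0.66 log units; beyond the scatter), and this is the first direct read of that change. Among the three aryl compounds, compound 1 alone stands apart, with steps beyond the scatter to both compound 2 and compound 4. No evidence on the cause of these steps is available.

Open, on these data alone, is whether an amine or a carboxylic acid in place of the acetyl of compound 1 would keep its number.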